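This account rests on a few compounds, and the source may have more. Where it says the series, first, only, none or still open, it means among the compounds named here.

Compound 1 `C=C(Br)C(=O)Nc1ccc(C(=O)/C=C/c2cccc(OC)c2OC)cc1` and compound 2 `C=C(Br)C(=O)Nc1ccc(C(=O)/C=C/c2ccc(OC)c(OC)c2OC)cc1` share one core. In a functional assay on MOLT-4 cells (Homo sapiens) for antiproliferative activity, with a stated time of 48 h (a lower number here means a stronger inhibitor, a higher number a weaker inhibitor), compound 1 gives 490 nM, and compound 2 gives 680 nM. The change between them is methoxy in place of hydrogen on an aromatic carbon, and it made a 1.4-fold higher number from compound 1 to compound 2 (0.14 log units; within the scatter). Compound 3 `COc1cc(/C=C/C(=O)c2ccc(N)cc2)cc(OC)c1` is built on another core; the difference between the two cores is not broken down here. In this assay compound 3 gives 7500 nM, the highest of the three numbers. Compound 4 `COc1cc(/C=C/C(=O)c2ccc(N)cc2)cc(OC)c1OC` carries the same kind of change relative to compound 3: methoxy in place of hydrogen on an aromatic carbon. The surroundings differ: in compound 4 the entering group sits ortho to two methoxy groups, whereas in compound 2 it sits ortho to a methoxy group and meta to a methoxy group. The expected step is a 1.1-fold higher number from compound 3 to compound 4 (0.05 log units; within the scatter), resting on compound 3 at 7500 nM and on a 1.4-fold higher number from compound 1 to compound 2 (0.14 log units; within the scatter) staying within the scatter. Compound 4 is expected to give about 8500 nM, most likely between 3000 nM and 24000 nM.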

Compound 4, half-maximal inhibitory concentration: 5600 nM
Beside the measured number, compound 4's estimate is 1.5-fold (0.18 log units) above it, and the stated range covers the measured number.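

In this assay, methoxy in place of hydrogen on an aromatic carbon gives a 1.3-fold lower number from compound 3 to compound 4 (0.13 log units; within the scatter). Within the limits of these two pairs, the change behaves alike on both cores: the same change on two cores in this assay, a 1.4-fold higher number (0.14 log units; within the scatter) from compound 1 to compound 2 and a 1.3-fold lower number (0.13 log units; within the scatter) from compound 3 to compound 4, 1.9-fold (0.27 log units) apart, within the scatter of two such steps. Among these compounds, this supports carrying the change between these two cores without expecting a step beyond the scatter in this assay, but it rests on only two pairs with different surroundings around the entering methoxy, and it does not show that the result holds on other cores or at other places on the ring.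

As far as these compounds go, whether a hydroxyl or an ethoxy group at the same place would behave like methoxy remains open. No pair shown isolates the difference between the two cores.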